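Aryl exchange at the chain carbon: maximal response notes

A few compounds are considered here, and "the series" means these few. Any claim that something is new, unique, unknown or untested is made for them only; others in the source may bear on it.

Measured so far:
compound 1, `N=C(NCCCc1c[nH]cn1)NCCC(c1ccccc1)c1ccccn1`: 1
compound 2, `N=C(NCCCc1c[nH]cn1)NCCC(c1ccccn1)c1ccccc1F`: 1

In a functional assay on cardiac atrium for agonist activity at histamine H2 receptor (Cavia porcellus) (a lower number here means a smaller maximal response, a higher number a larger maximal response), compound 2 stands level with compound 1 at the digits shown; both reach the full response of the reference agonist. Going by the values given here, the only measured step, no change at the digits printed from compound 1 to compound 2 (within the scatter), shows that exchanging a hydrogen for a fluorine on one of the two aromatic groups at the chain carbon left the maximal response where it was.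

Compound 3, `N=C(NCCCc1c[nH]cn1)NCCC(c1ccccn1)c1cccs1`, differs from compound 2 by thiophen-2-yl in place of 2-fluorophenyl on a saturated chain carbon bound to an aromatic carbon and a saturated chain carbon. Among the compounds with values here, the one step at hand bears on it directly, since it altered the same aromatic group at the same chain carbon and produced no change beyond the scatter. On that basis the maximal response of compound 3 is expected to stay at the level of compound 2, with an expected step of no change at the digits printed from compound 2 to compound 3 (within the scatter). The estimate for compound 3 is 1, expected to lie between 0.85 and 1.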

Compound 3, intrinsic activity: the largest response reached, as a fraction of the reference agonist's: 1
For compound 3 middle estimate and measured number coincide at the digits printed; the range from low to high includes it.
By their numbers in this assay, from the lowest: compounds 1, 2 and 3 (each within the scatter of the next).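

In this assay, thiophen-2-yl in place of 2-fluorophenyl gives no change at the digits printed from compound 2 to compound 3 (within the scatter), and thiophen-2-yl in place of phenyl gives no change at the digits printed from compound 1 to compound 3 (within the scatter). Going by these compounds alone, the earlier step touched only one hydrogen on the ring, whereas these steps replace the whole group on a saturated chain carbon bound to an aromatic carbon and a saturated chain carbon, putting a five-membered aromatic ring with 1 hetero atom where a six-membered aromatic ring of carbon only stood, and the maximal response stays level. No measurement at hand accounts for this lack of change.

Maximal response alone leaves open whether the concentration needed to reach it differs among these compounds. Also open, as far as these compounds go, is whether the response would hold with a saturated cyclohexyl group at this carbon, or with an amine or a carboxylic acid on the aromatic ring.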